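Adding an amino group to a potent deazapurine nucleoside

The source may report more compounds than this note shows. Statements on the series, on what has been measured and on what is new or still open speak of the compounds shown alone.

Measured compounds:
compound 1, `Nc1nc(N)c2c(-c3ccoc3)cn([C@@H]3O[C@H](CO)[C@@H](O)[C@H]3O)c2n1`: > 20000 nM
compound 2, `COc1nc(N)nc2c1c(-c1ccccc1)cn2[C@@H]1O[C@H](CO)[C@@H](O)[C@H]1O`: > 20000 nM
compound 3, `COc1ncnc2c1c(-c1ccoc1)cn2[C@@H]1O[C@H](CO)[C@@H](O)[C@H]1O`: 110 nM

Of the compounds shown here, three have been tested in a functional assay on CCRF-CEM cells (Homo sapiens), read by MTT assay, with a stated time of 72 h; a lower number here means a stronger inhibitor, a higher number a weaker inhibitor. Compound 1 gives > 20000 nM, which is a limit of the assay and not a number. Compound 2 likewise gives > 20000 nM, again a limit rather than a number. Within the data shown here, compound 3 is the only one with a real value, 110 nM, and it therefore stands as the one clearly active compound among the three. Compound 1 and compound 2 both carry an amino group on the six-membered ring of the shared core, and both sit at the limit of > 20000 nM in this assay, at which 2 of the 3 values shown sit; compound 3 lacks that group.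

The next compound, compound 4, `COc1nc(N)nc2c1c(-c1ccoc1)cn2[C@@H]1O[C@H](CO)[C@@H](O)[C@H]1O`, is compound 3 with one change: amino in place of hydrogen on an aromatic carbon. The amino group enters on an aromatic carbon of a six-membered aromatic ring with 2 nitrogen, between two ring nitrogen atoms, meta to the methoxy group. Nothing else moves.

Given that both amino-bearing compounds already measured sit at the limit of > 20000 nM in this assay, at which 2 of the 3 values shown sit, the expectation for compound 4 is a loss of potency well beyond the scatter, that is a step upward from a 73-fold higher number from compound 3 to compound 4 (1.86 log units; beyond the scatter). Compound 4 is estimated at 8000 nM, with a likely range from 1000 nM to 30000 nM, and a fair chance that only a limit is reported.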

Compound 4, half-maximal inhibitory concentration: > 20000 nM
Compound 4 gave a limit, no number; the forecaster's own chance of this, stated with the estimate: 45%; at least 2.5-fold (0.39 log units) between middle value and limit.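

In this assay, as far as these compounds go, amino in place of hydrogen on the aromatic carbon between two ring nitrogen atoms gives an at least 180-fold higher number from compound 3 to compound 4 (2.25 log units; beyond the scatter), and the true size of this step is unknown, as the value of compound 4 is a limit. Among these compounds, none of the earlier compounds differed from compound 3 in only one place, so they could not tie the loss to the amino group alone; here the furan-3-yl and methoxy groups stay fixed and the amino group is the only change. Compound 4 now joins the other two amino-bearing compounds at the same limit: the limit of > 20000 nM in this assay, at which 3 of the 4 values shown sit.

From the compounds shown here alone, the steps from compound 2 and from compound 1 to compound 4 cannot be read, with limits at both ends, so the effects of exchanging phenyl for furan-3-yl and amino for methoxy remain unknown in this amino-bearing series. Also open, going by these compounds, is whether the potency of compound 3, at 110 nM, would survive a methyl group or a fluorine atom on this same carbon, or whether hydrogen alone is tolerated there.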